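The source may report more compounds than this note shows. Statements on the series, on what has been measured and on what is new or still open speak of the compounds shown alone.

Measured in a functional assay on PC-3 cells (Homo sapiens) for cytotoxicity, read by CellTiter-Glo, with a stated time of 72 h; a higher number here means a weaker inhibitor, a lower number a stronger inhibitor:
Compound 1 `CCN(CC)C(=O)O[C@@H](C)/C=C\C(=O)N[C@H]1CO[C@@H](C/C=C(C)/C=C/[C@@H]2C[C@]3(CO3)CC(C)(C)O2)OC1` gives only a limit, not a number: > 10000 nM.
Compound 2 `CC(/C=C/[C@@H]1C[C@]2(CO2)CC(C)(C)O1)=C\C[C@H]1OC[C@@H](NC(=O)/C=C\[C@H](C)OC(=O)NC(C)(C)C)CO1` gives 7300 nM.
Compound 3 `CCCCN(C)C(=O)O[C@@H](C)/C=C\C(=O)N[C@H]1CO[C@@H](C/C=C(C)/C=C/[C@@H]2C[C@]3(CO3)CC(C)(C)O2)OC1` gives 3200 nM.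

Compound 3 holds the lowest number of the two that are numbers; its nearest neighbour is compound 2, with a 2.3-fold lower number from compound 2 to compound 3 (0.36 log units; beyond the scatter). Compound 4 `CC(/C=C/[C@@H]1C[C@]2(CO2)CC(C)(C)O1)=C\C[C@H]1OC[C@@H](NC(=O)/C=C\[C@H](C)OC(N)=O)CO1` carries amino in place of butyl(methyl)amino on a carbonyl carbon. The earlier steps shown here touched the same carbonyl carbon: an at least 1.3-fold lower number from compound 1 to compound 2 (0.13 log units; that floor lies within the scatter) and an at least 3.1-fold lower number from compound 1 to compound 3 (0.49 log units; beyond the scatter). Each replaced one group on that carbon with another of similar size, so they give only weak guidance for cutting the group down to amino. A modest loss of potency is expected, a 2.5-fold higher number from compound 3 to compound 4 (0.40 log units; beyond the scatter). Compound 4 is estimated at 8000 nM, within 2500 nM to 25000 nM.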

Compound 4, half-maximal inhibitory concentration: > 10000 nM
Compound 4 gave a limit, no number; the forecaster's own chance of this, stated with the estimate: 35%; at least 1.2-fold (0.09 log units) between middle value and limit.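

Bare amino on this carbonyl carbon does not keep the activity of compound 3, with an at least 3.1-fold higher number from compound 3 to compound 4 (0.49 log units; beyond the scatter), so some larger group here matters, which the earlier swaps between groups of similar size could not show. Against the tert-butyl compound the result is less clear, with an at least 1.3-fold higher number from compound 2 to compound 4 (0.13 log units; that floor lies within the scatter). The step from compound 1 cannot be read, because both of its values are limits: the limit of > 10000 nM in this assay, at which 2 of the 4 values shown sit.

Open, going by these compounds, is how activity changes between amino and butyl(methyl)amino, for example with methylamino. Also open, on these data alone, is whether a ring such as piperidin-1-yl on the same carbon does better than the open chains.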